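The source may hold more compounds than are shown below. What is called first, only, known or untested is meant among the compounds shown, and "the series" means these compounds.

Measured so far:
- compound 1 `c1ccc2c(c1)ccn2-c1nc(N2CCNCC2)nc2ccccc12`: 12.5 ug/mL
- compound 2 `COc1cc(OC)c(-c2nc(N3CCNCC3)nc3ccccc23)c(OC)c1`: 50 ug/mL
- compound 3 `CN1CCN(c2nc(-c3cn(C)c4ccccc34)c3ccccc3n2)CC1`: 50 ug/mL

Of the compounds shown here, three sharing one core have been tested in a functional assay on DU-145 cells (Homo sapiens) for antiproliferative activity, read by MTT assay; a lower number here means a stronger inhibitor, a higher number a weaker inhibitor. Compound 1 gives 12.5 ug/mL, the lowest of the three numbers. Among the measured compounds shown here, compound 2 gives 50 ug/mL and compound 3 gives 50 ug/mL, both a gap away from compound 1 that is beyond the usual scatter; no single-point step connects any pair of them, so these gaps only show what the two values are.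

The next compound, compound 4 `c1ccc(N2CCN(c3nc(-n4ccc5ccccc54)c4ccccc4n3)CC2)nc1`, differs from compound 1 in one place: pyridin-2-yl in place of hydrogen on an amine nitrogen in a ring. For the measured compounds named here, no measured pair isolates such a change, so there is no step to lean on. With nothing to indicate a direction, the expected step of a 1.0-fold lower number from compound 1 to compound 4 (0.02 log units; within the scatter) is none beyond the scatter, and compound 4 is estimated at 12 ug/mL, within the range 4 ug/mL to 40 ug/mL, a wide span given that no comparable change has been measured.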

Compound 4, half-maximal inhibitory concentration: 50 ug/mL
Estimate against measurement, compound 4: 4.2-fold (0.62 log units) below; measured number above the stated range.
By their numbers in this assay, from the lowest: compound 1; then compounds 2, 3 and 4 (each within the scatter of the next).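

In this assay, among the compounds shown here, pyridin-2-yl in place of hydrogen on the amine nitrogen in the ring gives a 4.0-fold higher number from compound 1 to compound 4 (0.60 log units; beyond the scatter), the first measured step at this position. This shows that the position is not indifferent to change: for this one group, the free hydrogen of compound 1 goes with the stronger inhibition. The data offer no measured explanation for this loss.

A single substituent cannot show whether the loss is tied to pyridin-2-yl itself, since a plain phenyl ring at the same nitrogen would be needed to test whether the ring nitrogen of that group matters. From the compounds shown here alone, it also remains open whether a small group, such as an ethyl or an acetyl, would be tolerated here or would bring a similar loss.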